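Fluoro for bromo on the aryl ring of compound 1

A few compounds are considered here, and "the series" means these few. Any claim that something is new, unique, unknown or untested is made for them only; others in the source may bear on it.

Measured compounds:
- compound 1 `Cn1c(=O)[nH]c2c(cnn2-c2ccccc2Br)c1=N`: in an assay on membranes from brain for binding affinity to adenosine receptor A1 (Rattus norvegicus), read by radioligand binding, tested at 20 uM (a lower number here means less inhibition, a higher number more inhibition at the concentration tested (going by the name of the read-out)), compound 1 gives 6%
- compound 2 `Cn1c(=O)[nH]c2c(cnn2-c2cccc(Br)c2)c1=N`: compound 2 gives 40%
- compound 3 `CCCCn1c(=O)[nH]c2c(cnn2-c2ccccc2)c1=N`: compound 3 gives 72%

Compound 1 stands lowest of the three numbers in this assay. Its nearest neighbour is compound 2, whose number lies higher by a gap beyond the scatter; compound 3 lies furthest, higher again by a gap beyond the scatter. Going by the values given here, no pair among the three differs in one place only, so no single step can be read off these data; the three values are taken as they stand.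

Compound 4 `Cn1c(=O)[nH]c2c(cnn2-c2ccccc2F)c1=N` is the next compound of the series and is not yet measured in this assay. It differs from compound 1 in one place: fluoro in place of bromo on an aromatic carbon. The halogen on the aromatic carbon changes, nothing else moves.

Without a measured step of this kind in the series, the expectation rests on the spread of the three numbers alone. The step is expected to be a number 14 percentage points higher from compound 1 to compound 4 (beyond the scatter), a modest rise that may not exceed the scatter. For compound 4 the estimate is 20%, with a range from 0% to 50%.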

Compound 4, a percentage reported as inhibition, at one concentration (the size of the read-out at that concentration, not a potency): 8%
The estimate for compound 4 lay 12 percentage points above the measured number; measured number inside the range.
By their numbers in this assay, from the lowest: compounds 1 and 4 (each within the scatter of the next); then compound 2; then compound 3.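

In this assay, fluoro in place of bromo on an aromatic carbon, ortho to a large group, gives a number 2 percentage points higher from compound 1 to compound 4 (within the scatter). Going by these compounds alone, this is the first single-place step, and at this position it does not separate the two halogens: compound 1 gives 6% and compound 4 gives 8%. Nothing at hand bears on why the two halogens read alike.

Open, on these data alone, is whether a group other than a halogen at this place, such as an amine, a methoxy group or a carboxylic acid, would give a number beyond the scatter of compound 1. Also open, as far as these compounds go, is whether the exchange of bromo for fluoro would read the same on a core carrying a longer chain, such as hexyl.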